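The source may report more compounds than this note shows. Statements on the series, on what has been measured and on what is new or still open speak of the compounds shown alone.

Measured compounds:
- compound 1, `O=c1cc(CSC(=S)N2CCCC2)oc2ccccc12`: 35800 nM
- compound 2, `O=c1cc(CSC(=S)N2CCCCC2)oc2ccccc12`: > 25000 nM
- compound 3, `O=c1c(CSC(=S)N2CCCCC2)coc2cc(Cl)ccc12`: 380 nM

Of the compounds shown here, three have been tested in a functional assay on MCF7 cells (Homo sapiens) for antiproliferative activity, read by MTT assay, with a stated time of 72 h; on this read-out lower numbers stand for stronger inhibition and higher numbers for weaker inhibition. Compound 1 gives 35800 nM in this assay. For compound 2 the result is only a limit of the assay, > 25000 nM, and not a number; the same limit, (the limit of > 25000 nM in this assay, at which 1 of the 3 values shown sits), is the one at which one of the three values sits. Compound 1 and compound 2 share a core and differ in one place, (pyrrolidin-1-yl in place of piperidin-1-yl on a thiocarbonyl carbon), but the step that the limit leaves unreadable from compound 2 to compound 1 cannot be read, since one end of it is a limit. Compound 3 gives 380 nM in this assay, the lowest of the two numbers; the difference between its core and the core of compound 2 is not broken down here.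

Compound 4, `O=c1c(CSC(=S)N2CCCC2)coc2cc(Cl)ccc12`, has not been measured. It carries the core of compound 3 and differs from it by pyrrolidin-1-yl in place of piperidin-1-yl on a thiocarbonyl carbon, the same change that leads from compound 2 to compound 1. For the measured compounds named here, that earlier step gives no readable size, so the only anchor for compound 4 is the value of compound 3. The step of a 1.3-fold higher number from compound 3 to compound 4 (0.12 log units; within the scatter) is therefore expected to be small, resting on compound 3 at 380 nM with wide uncertainty. Compound 4 is estimated at 500 nM, between 150 nM and 2000 nM.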

Compound 4, half-maximal inhibitory concentration: 600 nM
Beside the measured number, compound 4's estimate is 1.2-fold (0.08 log units) below it; the measured number falls inside the stated range.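

In this assay the change to pyrrolidin-1-yl in place of piperidin-1-yl on the thiocarbonyl carbon gives a 1.6-fold higher number from compound 3 to compound 4 (0.20 log units; within the scatter) and so, on this core, the two rings cannot be told apart from the ordinary scatter of repeated measurements. On the core of compound 2 the same change gives a step that cannot be read, because the result for compound 2 is a limit of the assay and not a number: the limit of > 25000 nM in this assay, at which 1 of the 4 values shown sits. The series therefore offers just one readable pair for this change, which shows that the swap is tolerated on one core but does not show that it behaves the same way on the other, since a comparison across cores needs a readable size at both ends.

For the compounds shown here, only two ring sizes appear on the thiocarbonyl carbon, so it remains open whether a morpholin-4-yl ring, with its added ring oxygen, or an open-chain diethylamino group would keep the activity seen on the core of compound 3. The cores of compound 2 and compound 3 also differ in more than one place, which leaves open how much of the gap between them belongs to the chlorine alone.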